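The source may hold more compounds than are shown below. What is called first, only, known or untested is meant among the compounds shown, and "the series" means these compounds.

Going by the values given here, compound 1 `CNC(=O)[C@@H](c1ccccc1)N1CCn2c(C)nc(Cl)c2[C@@H]1CCc1ccc(C(F)(F)F)cc1` gives 13 nM in a functional assay on CHO cells for antagonist activity at Orexin receptor type 2 (Homo sapiens), read by FLIPR and calcium flux (on this read-out higher numbers stand for weaker inhibition and lower numbers for stronger inhibition), the lowest number among the three compounds measured so far. Compound 2 `C=Cc1nc(CC)n2c1C(CCc1ccc(C(F)(F)F)cc1)N([C@@H](C(=O)NC)c1ccccc1)CC2` gives 23 nM, a number that lies within the usual scatter of the value of compound 1, so the two cannot be told apart on this read-out. Compound 3 `CCc1nc(C2CC2)c2n1CCN([C@@H](C(=O)NC)c1ccccc1)[C@H]2CCc1ccc(C(F)(F)F)cc1` gives 29 nM, and its gap to compound 1 is beyond the scatter. Among the compounds with values here, no pair of measured compounds differs in only one place, so compound 1 stands as a reference point rather than as the end of a known trend.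

Compound 4 `CNC(=O)[C@@H](c1ccccc1)N1CCn2c(COC)nc(Cl)c2[C@@H]1CCc1ccc(C(F)(F)F)cc1` has not yet been measured. It differs from compound 1 in a single place: methoxy in place of hydrogen on a saturated chain carbon bound to an aromatic carbon Seen one bond further out, the methyl becomes a methoxymethyl. The measured compounds give no guide to what this change does in this assay, since none of them carries this group. With compound 1 at 13 nM as the starting point, the step of a 1.5-fold higher number from compound 1 to compound 4 (0.19 log units; within the scatter) is expected to be no more than a modest move toward a higher number, quite possibly within the scatter. Compound 4 is therefore estimated at 20 nM, with a range from 6 nM to 65 nM.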

Compound 4, half-maximal inhibitory concentration: 25 nM
For compound 4 the middle estimate is 1.3-fold (0.10 log units) below the measured one, and the stated range covers the measured number.
By their numbers in this assay, from the lowest: compounds 1, 2, 4 and 3 (each within the scatter of the next, the first and the last beyond it).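

In this assay, methoxy in place of hydrogen on a saturated chain carbon bound to an aromatic carbon gives a 1.9-fold higher number from compound 1 to compound 4 (0.28 log units; within the scatter), so on this read-out the methoxymethyl compound cannot be told apart from its methyl parent. Going by these compounds alone, this is the first comparison in which only one place differs, and it shows that this position can carry the added oxygen and carbon, including one new hydrogen-bond acceptor, without a difference that rises beyond the scatter. No measurement shown speaks to what lies behind this result, and a single step within the scatter sets no trend for this position.

The compounds shown leave open how this position would read with a hydroxymethyl, an aminomethyl, a carboxylic acid or a longer chain such as ethoxymethyl, any of which would test how much further the group on this carbon can be changed. As far as these compounds go, it also remains open whether the change from methyl to methoxymethyl would read the same way on a core other than that of compound 1.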